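This account rests on a few compounds, and the source may have more. Where it says the series, first, only, none or still open, it means among the compounds named here.

In an assay on CHO cells for displacement of a labelled ligand from adenosine receptor A3 (Homo sapiens), with a stated time of 60 min (on this read-out lower numbers stand for stronger inhibition and higher numbers for weaker inhibition), compound 2 `CCCCC#Cc1nc(NCc2cccc(Br)c2)c2ncn([C@@H]3SC[C@@H](O)[C@H]3O)c2n1` gives 24 nM, the lowest of the three numbers measured. Compound 1 `CCCCC#Cc1nc2c(N)ncnc2n1[C@@H]1OC[C@@H](O)[C@H]1O` gives 31.7 nM, which lies within the scatter of compound 2. Compound 3 `CCCCC#Cc1nc(NCc2cccc(Br)c2)c2ncn([C@@H]3OC[C@@H](O)[C@H]3O)c2n1` gives 67 nM, and the step of a 2.8-fold higher number from compound 2 to compound 3 (0.45 log units; beyond the scatter) lies beyond the scatter. Compound 4 `CCCCC#Cc1nc(NCc2cccc(Cl)c2)c2ncn([C@@H]3SC[C@@H](O)[C@H]3O)c2n1` has not yet been measured in this assay. It differs from compound 2 by chloro in place of bromo on an aromatic carbon. Within the data shown here, no measured step concerns this exchange: the only measured step involves the ring on the aromatic nitrogen and says nothing about the halogen. The step of a 1.2-fold higher number from compound 2 to compound 4 (0.07 log units; within the scatter) is therefore expected to stay within the scatter, in no clear direction. In this assay, compound 4 is estimated at 28 nM, with a range from 12 nM to 65 nM.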

Compound 4, inhibition constant: 24 nM
Estimate against measurement, compound 4: 1.2-fold (0.07 log units) above, within the range that was stated.
By their numbers in this assay, from the lowest: compounds 2, 4 and 1 (each within the scatter of the next); then compound 3.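

In this assay, among these compounds, the change from 3-bromobenzyl to 3-chlorobenzyl gives no change at the digits printed from compound 2 to compound 4 (within the scatter) and is the first step to read this halogen, as the earlier step concerned only the ring on the aromatic nitrogen. At this place on the ring, this read-out does not tell bromo and chloro apart. Nothing measured here offers an explanation for this.

The compounds shown leave open whether a methoxy group, a nitrile or an amine at this place would change the number. They also leave open whether the same exchange reads alike with the 3,4-dihydroxyoxolan-2-yl group of compound 3.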